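Fluoro for Methoxy on a Selenocyanate Carbamate

The source may hold more compounds than are shown below. What is called first, only, known or untested is meant among the compounds shown, and "the series" means these compounds.

Compound 1 `COc1ccc(OC(=O)Nc2ccc([Se]C#N)cc2)cc1`: 7500 nM
Compound 2 `O=C(Nc1ccc([Se][Se]c2ccc(NC(=O)OCc3ccccc3)cc2)cc1)OCc1ccccc1`: 100 nM
Compound 3 `CCOC(=O)Nc1ccc([Se][Se]c2ccc(NC(=O)OCC)cc2)cc1`: 28800 nM

Of the compounds shown here, three have been measured in a functional assay on PC-3 cells (Homo sapiens) for cytotoxicity, read by MTT assay, with a stated time of 72 h; a lower number here means a stronger inhibitor of growth, a higher number a weaker inhibitor of growth. Compound 2 gives the lowest number, 100 nM. Compound 1 stands second highest of the three, with 7500 nM; its nearest neighbour is compound 3 at 28800 nM, a gap beyond the scatter, and compound 2 lies furthest from it, also beyond the scatter. Compound 4 `N#C[Se]c1ccc(NC(=O)Oc2ccc(F)cc2)cc1` has not yet been measured. It differs from compound 1 by fluoro in place of methoxy on an aromatic carbon. Among the compounds with values here, no measured pair shows this change, so the size of its step in this assay is unknown; the expected step from compound 1 to compound 4 is a 1.1-fold lower number from compound 1 to compound 4 (0.03 log units; within the scatter), nothing beyond the scatter in either direction. For compound 4 the estimate is 7000 nM, with a range from 2500 nM to 20000 nM.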

Compound 4, concentration for 50% growth inhibition: 11800 nM
Compound 4: middle estimate off by 1.7-fold (0.23 log units), on the low side, within the range that was stated.
By their numbers in this assay, from the lowest: compound 2; then compounds 1 and 4 (each within the scatter of the next); then compound 3.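

In this assay, fluoro in place of methoxy on an aromatic carbon, para to a large group, gives a 1.6-fold higher number from compound 1 to compound 4 (0.20 log units; within the scatter) and so leaves the read-out within the scatter. This is the only pair among the compounds shown that differs in one place, and it shows that this change at this position produces no step beyond the scatter. No other data bear on this result. Going by these compounds, whether an amine, a carboxylic acid or a longer chain at this carbon would also stay within the scatter remains open. Compound 2 and compound 3 differ from compound 1 in more than one place, so those steps cannot be read.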